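A Cyano Group Added to the Selenium of Compound 2

The compounds below may be only part of what the source reports. "The series", "measured", "known", "first", "only" and "open" are said of these compounds alone.

Measured compounds:
compound 1 `N#CSc1nc2ccccc2s1` gives 42000 nM
compound 2 `O=C1c2ccccc2C(=O)N1C[SeH]` gives 6400 nM

Both were tested in a functional assay on PC-3 cells (Homo sapiens) for cytotoxicity, read by MTT assay, with a stated time of 72 h; a lower number here means a stronger inhibitor of growth, a higher number a weaker inhibitor of growth. Compound 2 has the lower of the two numbers, and its gap to compound 1 lies beyond the usual scatter. Compound 3 `N#C[Se]CN1C(=O)c2ccccc2C1=O` has not yet been tested; it carries cyano in place of hydrogen on a selenium. Among the measured compounds shown here, no step between measured compounds shows how such a change acts, so only a small step is expected. Compound 3 is expected to give 5000 nM in this assay, within a range from 1500 nM to 20000 nM. The estimated step of a 1.3-fold lower number from compound 2 to compound 3 (0.11 log units; within the scatter) is therefore expected to stay within the usual scatter.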

Compound 3, concentration for 50% growth inhibition: 11200 nM
Compound 3: middle estimate off by 2.2-fold (0.35 log units), on the low side, and the stated range covers the measured number.
By their numbers in this assay, from the lowest: compounds 2 and 3 (each within the scatter of the next); then compound 1.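

In this assay, cyano in place of hydrogen on a selenium whose other neighbour is a saturated chain carbon gives (a 1.8-fold higher number from compound 2 to compound 3 (0.24 log units; within the scatter)). Among the compounds shown here, this is the first step read at this position, and it leaves compound 2 and compound 3 within the scatter of each other, so hydrogen and cyano on this selenium cannot be told apart here. Nothing available bears on what lies behind this result. Going by these compounds, whether a methyl group, a longer chain or an amine on the selenium would read the same remains open.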